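Swapping a dichlorophenyl for a fluorophenyl on a thiadiazole

The compounds below may be only part of what the source reports. "The series", "measured", "known", "first", "only" and "open" are said of these compounds alone.

Of the compounds shown here, three have been tested in a functional assay on the whole organism for inhibition, with Mythimna separata as the target, with a stated time of 5 days; on this read-out higher numbers stand for an effect only at larger amounts of compound and lower numbers for an effect already at smaller amounts. Compound 1 `CC(C)(C)n1ncc(OCc2nnc(-c3ccc(Cl)cc3Cl)s2)c(Cl)c1=O` gives 62.2 ug/mL, the lowest of the two plain numbers shown. Compound 2 `CCCCn1ncc(OCc2nnc(-c3ccc(F)cc3)o2)c(Cl)c1=O` gives 162 ug/mL in this assay, a higher number than compound 1 by a margin beyond the usual scatter. Compound 3 `Cc1cc(C)cc(-c2nnc(COc3cnn(C(C)(C)C)c(=O)c3Cl)o2)c1` reaches only a limit of the assay, > 300 ug/mL, which the evidence records as the limit of > 300 ug/mL in this assay, at which 1 of the 3 values shown sits. No pair among these differs in one place only, so no single change can be tied to a measured step.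

Compound 4 `CC(C)(C)n1ncc(OCc2nnc(-c3ccc(F)cc3)s2)c(Cl)c1=O` has not been measured. It differs from compound 1 by 4-fluorophenyl in place of 2,4-dichlorophenyl on an aromatic carbon. For the measured compounds named here, since no step from one measured compound to another isolates this change, the expectation rests on the general spread seen here: compound 2, which also carries a 4-fluorophenyl but differs elsewhere, gives 162 ug/mL. Compound 4 is therefore expected to give about 130 ug/mL, within a range from 50 ug/mL to 300 ug/mL. This estimate means an expected step of a 2.1-fold higher number from compound 1 to compound 4 (0.32 log units; beyond the scatter) toward a higher number, beyond the scatter.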

Compound 4, half-maximal effective concentration: 21.5 ug/mL
Estimate against measurement, compound 4: 6.0-fold (0.78 log units) above; the whole stated range lies above it.
By their numbers in this assay, from the lowest: compound 4; then compound 1; then compound 2. At a limit, above all of these: compound 3.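

For the compounds shown here, this is the first measured step that isolates a single change. On the aromatic carbon of the five-membered ring with 2 nitrogen and 1 sulfur, 4-fluorophenyl in place of 2,4-dichlorophenyl gives a 2.9-fold lower number from compound 1 to compound 4 (0.46 log units; beyond the scatter) in this assay on an otherwise unchanged core. The two chlorine atoms are therefore not needed for activity at this position, and no measured property on hand accounts for the step.

The swap removes both chlorine atoms and adds a fluorine at once, so the compounds shown cannot say which part of the change matters. A plain phenyl or a 4-chlorophenyl at this position would separate the two, and a 4-methoxyphenyl would test whether a halogen is needed there at all.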